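The compounds below may be only part of what the source reports. "The series", "measured", "known", "first", "only" and "open" are said of these compounds alone.

Of the compounds shown here, two that share the same nitrile-bearing acrylamide chain have been tested in a functional assay on SJ-G2 cells (Homo sapiens) for inhibition, read by MTT assay, with a stated time of 72 h; a lower number here means a stronger inhibitor of growth, a higher number a weaker inhibitor of growth. Compound 1 `N#C/C(=C\c1ccc(Cl)cc1)C(=O)c1ccc[nH]1` gives 37000 nM in this assay, a weak inhibition of growth. Compound 2 `COc1ccc(CNC(=O)/C(C#N)=C/c2ccc[nH]2)cc1` returns > 50000 nM in this assay, which is a limit of the assay and not a number. Compound 2 therefore stands at the limit of > 50000 nM in this assay, at which 1 of the 2 values shown sits, the weak end of what has been measured, without an exact figure of its own. Compound 3 `COc1ccc(CNC(=O)/C(C#N)=C/c2ccco2)cc1` has not been measured yet; it differs from compound 2 by furan-2-yl in place of 1H-pyrrol-2-yl on a double-bonded chain carbon bound to a double-bonded chain carbon. Among the compounds with values here, no measured step between two compounds that differ in one place exists in this small set, so the size of such a ring exchange has not been seen here. One five-membered aromatic ring gives way to another, and a hydrogen-bond donor is traded for a hydrogen-bond acceptor. Compound 3 is expected to shift by a number no higher from compound 2 to compound 3 (the limit leaves the size open) in this assay, a step within the usual scatter rather than a real change. Compound 3 is thus estimated at 50000 nM in this assay, with a range from 20000 nM to 120000 nM, and it may again come back as a limit.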

Compound 3, concentration for 50% growth inhibition: 31000 nM
For compound 3 the middle estimate is 1.6-fold (0.21 log units) above the measured one; the measured number falls inside the stated range.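

In this assay, within the data shown here, furan-2-yl in place of 1H-pyrrol-2-yl on a double-bonded chain carbon bound to a double-bonded chain carbon gives the first step that can be read in this set: an at least 1.6-fold lower number from compound 2 to compound 3 (0.20 log units; that floor lies within the scatter). Compound 3 gives an exact figure, 31000 nM, so one end of this ring exchange is now fixed, and the exchange of a hydrogen-bond donor for a hydrogen-bond acceptor at this place is no longer unseen. The printed size is only a floor, so the step may be a real change or may not, since the value of compound 2 is a limit of the assay and not a number: the limit of > 50000 nM in this assay, at which 1 of the 3 values shown sits.

The compounds shown leave open whether the ring's hydrogen-bond donor or the identity of the ring itself governs this step, and an N-methylpyrrol-2-yl ring or a thiophen-2-yl ring at this place would help to separate the two. They also leave open whether a phenyl ring there would behave like furan-2-yl, and how far any such exchange would carry over to other groups on the amide nitrogen.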